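Fluoro substitution on the dinitro oxindole core

The source may report more compounds than this note shows. Statements on the series, on what has been measured and on what is new or still open speak of the compounds shown alone.

Measured compounds:
compound 1 `O=C1Nc2ccccc2C1(c1c[nH]c2ccc([N+](=O)[O-])cc12)c1c[nH]c2ccc([N+](=O)[O-])cc12` gives 23400 nM in a functional assay on HepG2 cells (Homo sapiens) for cytotoxicity, read by MTT assay, with a stated time of 48 h; on this read-out lower numbers stand for stronger inhibition and higher numbers for weaker inhibition
compound 2 `O=C1Nc2ccc(F)cc2C1(c1c[nH]c2ccccc12)c1c[nH]c2ccccc12` gives 6600 nM in this assay

Among the measured compounds shown here, compound 1 has the higher of the two numbers recorded so far in this assay; the only other measured compound, compound 2, sits at a lower number, and the gap between the two lies beyond the scatter. For the measured compounds named here, compound 2 differs from compound 1 in more than one place, so no single step between them can be read off.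

The unmeasured compound 3 `O=C1Nc2ccc(F)cc2C1(c1c[nH]c2ccc([N+](=O)[O-])cc12)c1c[nH]c2ccc([N+](=O)[O-])cc12` follows directly from compound 1 through one change: fluoro in place of hydrogen on an aromatic carbon. Compound 2 carries the same fluoro on its core, but without the nitro groups, so the data give no isolated measure of what this fluoro does on the dinitro scaffold.

With no clean comparison available, the step from compound 1 to compound 3 is expected to be small in this assay, a 1.3-fold lower number from compound 1 to compound 3 (0.11 log units; within the scatter), leaning toward a slightly lower number but within the scatter. On that basis compound 3 is estimated at 18000 nM, with a range from 7000 nM to 45000 nM.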

Compound 3, half-maximal inhibitory concentration: 23800 nM
Compound 3: middle estimate off by 1.3-fold (0.12 log units), on the low side, within the range that was stated.
By their numbers in this assay, from the lowest: compound 2; then compounds 1 and 3 (each within the scatter of the next).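

In this assay, among the compounds shown here, fluoro in place of hydrogen on an aromatic carbon gives a 1.0-fold higher number from compound 1 to compound 3 (0.01 log units; within the scatter) and so supplies the first isolated reading of this change on the core of compound 1. At this position, on a six-membered aromatic ring of carbon only, meta to a fused ring and para to a fused ring, hydrogen and fluoro cannot be told apart on this read-out while both nitro groups are present. Nothing available bears on why this change leaves the read-out within the scatter.

On these data alone, the steps from compound 2 to the other two compounds cannot be read: those pairs differ in more than one place, and what this fluoro does on a core without the nitro groups remains open. Also open, as far as these compounds go, is whether another group at this position, such as an amine, a methoxy group or a carboxylic acid, would separate from hydrogen on the core of compound 1 in this assay.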